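Trifluoromethyl in place of methyl on compound 2

A few compounds are considered here, and "the series" means these few. Any claim that something is new, unique, unknown or untested is made for them only; others in the source may bear on it.

Of the compounds shown here, two have been measured so far in a functional assay on SPCA2 cells (Homo sapiens) for cytotoxicity, read by MTT assay, with a stated time of 2 days; on this read-out higher numbers stand for weaker inhibition and lower numbers for stronger inhibition. In this assay, compound 1 `O=[N+]([O-])c1ccc2c(c1)/C(=N\O)C(c1c[nH]c3ccc([N+](=O)[O-])cc13)=N2` gives 11200 nM, while compound 2 `Cc1ccc(CO/N=C2/C(c3c[nH]c4ccccc34)=Nc3ccccc32)cc1` gives 25400 nM. Compound 2 therefore holds the higher of the two numbers, meaning the weaker inhibition of the pair, and the gap between them lies beyond the scatter.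

The next compound is compound 3 `FC(F)(F)c1ccc(CO/N=C2/C(c3c[nH]c4ccccc34)=Nc3ccccc32)cc1`, which differs from compound 2 in a single place: trifluoromethyl in place of methyl on an aromatic carbon. This is trifluoromethyl in place of methyl on an aromatic carbon, para to a large group, turning 4-methylphenyl into 4-(trifluoromethyl)phenyl. Within the data shown here, no measured pair shows this change, and compound 1 differs from compound 2 in more than one place, so the data give no direct guide to its size or direction. Taking compound 2 at 25400 nM as the only anchor, no step beyond the scatter is expected in this assay. The estimated change is a 1.3-fold lower number from compound 2 to compound 3 (0.10 log units; within the scatter), and it is expected to stay within the scatter. The expected value for compound 3 is 20000 nM, with an estimated range from 8000 nM to 50000 nM.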

Compound 3, half-maximal inhibitory concentration: 21200 nM
Beside the measured number, compound 3's estimate is 1.1-fold (0.03 log units) below it, within the range that was stated.
By their numbers in this assay, from the lowest: compounds 1, 3 and 2 (each within the scatter of the next, the first and the last beyond it).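

Among these compounds, this is the first pair that differs in one place, and in this assay it gives a 1.2-fold lower number from compound 2 to compound 3 (0.08 log units; within the scatter). On this aromatic carbon, para to a large group, trifluoromethyl and methyl therefore cannot be told apart in this read-out, even though four heavy atoms enter where one leaves and neither group carries hydrogen-bond donors or acceptors. Compound 1 could not show this, since it differs from compound 2 in more than one place, and nothing at hand offers an explanation for the result.

The compounds shown leave open whether this position tolerates any change, since a single swap between two uncharged groups says little about an amine, a carboxylic acid or a longer chain such as butyl on the same carbon, or about plain hydrogen there. From the compounds shown here alone, it also remains open whether the same change would read alike on the core of compound 1, or in cells other than those of this assay.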